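Fluoro for methoxy at the aryl group of compound 2

The compounds below may be only part of what the source reports. "The series", "measured", "known", "first", "only" and "open" are said of these compounds alone.

In a functional assay on WM 266-4 cells (Homo sapiens) for inhibition, read by MTT assay, with a stated time of 24 h (a lower number here means a stronger inhibitor of growth, a higher number a weaker inhibitor of growth), compound 2 `COc1ccc(C2=NN(C(=O)c3ccc4c(c3)OCCO4)C(c3ccc(OC)cc3)C2)cc1` gives 9890 nM, the highest of the three numbers. Compound 1 `COc1ccc(C2CC(c3ccccc3)=NN2C(=O)c2ccc3c(c2)OCCO3)cc1` gives 8370 nM, and the step of a 1.2-fold higher number from compound 1 to compound 2 (0.07 log units; within the scatter) shows the two within the scatter of each other. Within the data shown here, compound 3 `O=C(C1COc2ccccc2O1)N1N=C(c2ccccc2)CC1c1cccc(F)c1` gives 1450 nM, but it differs from compound 2 in more than one place and offers no single step. Compound 4 `COc1ccc(C2=NN(C(=O)c3ccc4c(c3)OCCO4)C(c3ccc(F)cc3)C2)cc1` has fluoro in place of methoxy on an aromatic carbon, that is, 4-methoxyphenyl becomes 4-fluorophenyl. Among the measured compounds shown here, the only step that bears on this site is the one from compound 1 to compound 2, which was within the scatter, so a small change is expected. For compound 4 the expected step is a 1.3-fold lower number from compound 2 to compound 4 (0.12 log units; within the scatter), giving an estimate of 7500 nM with a range from 3000 nM to 19000 nM.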

Compound 4, concentration for 50% growth inhibition: 3780 nM
Compound 4: middle estimate off by 2.0-fold (0.30 log units), on the high side; low and high end bracket the measured number.
By their numbers in this assay, from the lowest: compound 3; then compound 4; then compounds 1 and 2 (each within the scatter of the next).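

In this assay, replacing 4-methoxyphenyl with 4-fluorophenyl gives a 2.6-fold lower number from compound 2 to compound 4 (0.42 log units; beyond the scatter), so this change moves the number beyond the scatter, whereas the earlier change of hydrogen to methoxy gave only a 1.2-fold higher number from compound 1 to compound 2 (0.07 log units; within the scatter). The step is modest, but it shows that the number responds to the group on this aromatic ring. Nothing available accounts for the difference. The compounds shown leave open how a chloro, an amino or a trifluoromethyl group would compare with fluoro here, and whether fluoro would give a similar step on another core.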